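Chalcogen aryl amine series: isobutyl on the amine nitrogen

The compounds below may be only part of what the source reports. "The series", "measured", "known", "first", "only" and "open" are said of these compounds alone.

Compound 1 `CCCC[Se]c1ccc(C(C)N)cc1` is the starting point of the step considered here. In a functional assay, read by spectrophotometry, with a stated time of 30 min (on this read-out lower numbers stand for stronger inhibition and higher numbers for weaker inhibition), compound 1 gives only a limit, > 100 ug/mL, and not a number. Compound 1 thus sits at the limit of > 100 ug/mL in this assay, at which 1 of the 3 values shown sits. Compound 2 `CCCC[Te]c1ccc(/C(C)=N/N)cc1` and compound 3 `CCCC[Te]c1ccc(C(C)NCc2ccccc2)cc1` carry a different core and are measured with numbers: in this assay compound 2 gives 5.08 ug/mL and compound 3 gives 11.4 ug/mL. Compound 4 `CCCC[Se]c1ccc(C(C)NCC(C)C)cc1` differs from compound 1 by isobutyl in place of hydrogen on an amine nitrogen. For the measured compounds named here, no step between measured compounds gauges this change, and the starting value is a limit, so the expected step that the limit leaves unreadable from compound 1 to compound 4 is small, in no firm direction. Compound 4 is estimated at 120 ug/mL, within 35 ug/mL to 400 ug/mL, with a fair chance that this assay again reports only a limit.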

Compound 4, half-maximal inhibitory concentration: > 100 ug/mL
Compound 4: no number, only a limit; the forecaster's own chance of this, stated with the estimate: 55%; the middle value lies beyond the limit too.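

In this assay compound 1 and compound 4 both give only a limit, so no step can be read between them: the limit of > 100 ug/mL in this assay, at which 2 of the 4 values shown sit.

The compounds shown leave open whether isobutyl in place of hydrogen on an amine nitrogen changes inhibition on this shared core at all.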